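Adding a methoxy group to the benzyl arm of compound 2

The source may report more compounds than this note shows. Statements on the series, on what has been measured and on what is new or still open speak of the compounds shown alone.

Of the compounds shown here, two have been measured in a functional assay on NCI-H460 cells (Homo sapiens) for antiproliferative activity, read by WST assay, with a stated time of 72 h; on this read-out lower numbers stand for stronger inhibition and higher numbers for weaker inhibition. Compound 1 `CCCCCCCCCCCCCC/N=c1\nc(N)c2ncn(Cc3ccccc3)c2c(N)n1` gives 6750 nM, and compound 2 `CCCCCCCC/N=c1\nc(N)c2ncn(Cc3ccccc3)c2c(N)n1` gives 7450 nM. The step from compound 1 to compound 2, a 1.1-fold higher number from compound 1 to compound 2 (0.04 log units; within the scatter), shortens the long chain and leaves the number essentially unchanged. On these two numbers compound 2 stands highest, with compound 1 close beside it within the scatter.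

Compound 3 `CCCCCCCC/N=c1\nc(N)c2ncn(Cc3ccc(OC)cc3)c2c(N)n1` differs from compound 2 by methoxy in place of hydrogen on an aromatic carbon. Among the compounds with values here, no measured step touches the benzyl ring; the only measured step concerns the chain and is within the scatter, so it bears on this change only indirectly. Without a comparable step, the expectation is no change beyond the scatter: the step from compound 2 to compound 3 is estimated as a 1.1-fold lower number from compound 2 to compound 3 (0.03 log units; within the scatter). For compound 3 in this assay the expected value is 7000 nM, with a range from 3000 nM to 16000 nM.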

Compound 3, half-maximal inhibitory concentration: 4200 nM
Compound 3: middle estimate off by 1.7-fold (0.22 log units), on the high side; the measured number falls inside the stated range.
By their numbers in this assay, from the lowest: compounds 3, 1 and 2 (each within the scatter of the next).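

Methoxy on an aromatic carbon of the benzyl ring, para to a large group, is the first change shown at this ring rather than the chain, and in this assay it gives a 1.8-fold lower number from compound 2 to compound 3 (0.25 log units; within the scatter) and so remains within the usual scatter. On this pair, then, exchanging benzyl for 4-methoxybenzyl is tolerated, with no difference that can be separated from repeat-measurement variation. Nothing shown here offers an explanation for the number compound 3 gives.

Going by these compounds, whether an amine, a carboxylic acid or ethoxy at this same ring carbon would move the number beyond the scatter remains open. Also open, on these data alone, is whether methoxy would behave the same way on another carbon of the ring, or on the ring of compound 1 with its longer chain.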